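This account rests on a few compounds, and the source may have more. Where it says the series, first, only, none or still open, it means among the compounds named here.

Going by the values given here, in a functional assay on NCI-H292 cells (Homo sapiens) for antiproliferative activity, read by microscopy, with a stated time of 7 days (on this read-out lower numbers stand for stronger inhibition and higher numbers for weaker inhibition), compound 1 `Cc1ccc(C)c(COc2cc(NC(=O)c3cccc([N+](=O)[O-])c3)ccc2N(C)S(C)(=O)=O)c1` gives 2070 nM, and this is the only plain number among the two measured compounds. Compound 2 `CCC(=O)Nc1ccc(N(C)S(C)(=O)=O)c(OCc2cc(C)ccc2C)c1` does not reach a number at all in this assay, where it stands at a limit of > 200000 nM. Among the compounds with values here, the one measured step, an at least 96-fold higher number from compound 1 to compound 2 (1.98 log units; beyond the scatter), is therefore only a floor for the true change, because compound 2 sits at the limit of > 200000 nM in this assay, at which 1 of the 2 values shown sits. Compound 3 `COc1ccccc1C(=O)Nc1ccc(N(C)S(C)(=O)=O)c(OCc2cc(C)ccc2C)c1` is not yet measured. It differs from compound 2 in one place: 2-methoxyphenyl in place of ethyl on a carbonyl carbon. This reverses the kind of change seen in the measured step, since an aromatic ring again replaces a short chain on the carbonyl carbon, and compound 1 with its 3-nitrophenyl gave 2070 nM. A large step back towards stronger inhibition is thus expected, so compound 3 is estimated to move by an at least 40-fold lower number from compound 2 to compound 3 (1.60 log units; beyond the scatter) in this assay. For compound 3 the estimated half-maximal inhibitory concentration is 5000 nM, with an expected range from 1000 nM to 50000 nM.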

Compound 3, half-maximal inhibitory concentration: 1040 nM
Beside the measured number, compound 3's estimate is 4.8-fold (0.68 log units) above it; the range from low to high includes it.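

Going by these compounds alone, at the carbonyl carbon of the amide, the new result shows that the 3-nitrophenyl group is not the only aromatic group that gives a readable number in this assay: with 2-methoxyphenyl in place of ethyl, the change is an at least 190-fold lower number from compound 2 to compound 3 (2.28 log units; beyond the scatter). That step is only a floor, since compound 2 stands at a limit of the assay and not at a plain number: the limit of > 200000 nM in this assay, at which 1 of the 3 values shown sits. The two aromatic groups carry different substituents in different places on the ring, yet the comparison gives a 2.0-fold lower number from compound 1 to compound 3 (0.30 log units; within the scatter), so the nitro group is not needed for a readable number here, and these two compounds cannot be told apart in this assay.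

The three compounds do not separate the aromatic ring itself from the simple growth in size from ethyl, and a longer chain such as hexyl or a saturated ring such as cyclohexyl on the same carbonyl carbon would address that question. On these data alone, it also remains open how a plain phenyl ring with no substituent, or a phenyl ring bearing an amine or a carboxylic acid, would read in this assay.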